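The source may hold more compounds than are shown below. What is called first, only, known or untested is meant among the compounds shown, and "the series" means these compounds.

Compound 1 `Cc1ccc(NC(=O)/C=C/C(=O)N2C/C(=C\c3ccccc3)C(=O)/C(=C/c3ccccc3)C2)cc1` sits at the high end of the three numbers in hand: in a functional assay on CCRF-CEM cells (Homo sapiens) for cytotoxicity (on this read-out higher numbers stand for weaker inhibition and lower numbers for stronger inhibition), compound 1 gives 1100 nM. Compound 2 `O=C(/C=C/C(=O)N1C/C(=C\c2ccc([N+](=O)[O-])cc2)C(=O)/C(=C/c2ccc([N+](=O)[O-])cc2)C1)Nc1ccc(Cl)c(Cl)c1` gives 380 nM, and compound 3 `CC(=O)c1ccc(NC(=O)/C=C/C(=O)N2C/C(=C\c3ccc([N+](=O)[O-])cc3)C(=O)/C(=C/c3ccc([N+](=O)[O-])cc3)C2)cc1` gives 360 nM. Both of these lie well below compound 1, but each differs from compound 1 in more than one place, so only their values can be compared, not a single step.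

Compound 4 `O=C(/C=C/C(=O)N1C/C(=C\c2ccccc2)C(=O)/C(=C/c2ccccc2)C1)Nc1ccc(Cl)cc1` departs from compound 1 by one change, (chloro in place of methyl on an aromatic carbon). For the measured compounds named here, no measured pair carries exactly this exchange. Going by the values given here, the only one-point step available is a 1.1-fold lower number from compound 2 to compound 3 (0.02 log units; within the scatter), a change of the group on the same amide-type nitrogen, and it stayed within the scatter. That step bears on the present one only loosely, but it suggests that a small change on this ring need not move this assay far. Compound 4 is therefore expected to land near compound 1, with the step of a 1.2-fold lower number from compound 1 to compound 4 (0.09 log units; within the scatter) estimated as at most modest. The estimate for compound 4 is 900 nM, within a range from 400 nM to 2000 nM.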

Compound 4, half-maximal inhibitory concentration: 840 nM
Compound 4: middle estimate off by 1.1-fold (0.03 log units), on the high side; the measured number falls inside the stated range.
By their numbers in this assay, from the lowest: compounds 3 and 2 (each within the scatter of the next); then compounds 4 and 1 (each within the scatter of the next).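

For the compounds shown here, this is the first direct reading at this position: in this assay, the exchange of methyl for chloro, on an aromatic carbon para to a large group, gives a 1.3-fold lower number from compound 1 to compound 4 (0.12 log units; within the scatter). On the core of compound 1, then, these two single-atom groups cannot be told apart by this read-out. Going by these compounds alone, the earlier step, a 1.1-fold lower number from compound 2 to compound 3 (0.02 log units; within the scatter), involved different groups on a differently substituted core, so the present step is the first to show a small exchange staying within the scatter on this core.

As far as these compounds go, whether an amine, a carboxylic acid or a methoxy group at this place would also stay within the scatter remains open. So does whether methyl and chloro would match on the core of compound 3. Nothing measured here accounts for the result.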